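The compounds below may be only part of what the source reports. "The series", "measured", "known", "first", "only" and "open" are said of these compounds alone.

Measured so far:
Compound 1, `CC(C)C(c1ccc(-c2ccc3cccc(F)c3c2)[nH]c1=O)N1CCNC1=O`, gives 28 nM in a functional assay on CHO cells for antagonist activity at prostaglandin E2 receptor EP3 subtype (Homo sapiens), read by cAMP accumulation; on this read-out lower numbers stand for stronger inhibition and higher numbers for weaker inhibition.
Compound 2, `CC(C)C(Cc1nnn[nH]1)c1ccc(-c2ccc3cccc(F)c3c2)[nH]c1=O`, gives 134 nM in this assay.

For the measured compounds named here, of these two numbers, compound 2 holds the higher one, that is the weaker inhibition; the only step that joins them is a 4.8-fold higher number from compound 1 to compound 2 (0.68 log units; beyond the scatter). Compound 3, `CC(C)C(Cc1noc(=O)[nH]1)c1ccc(-c2ccc3cccc(F)c3c2)[nH]c1=O`, has not yet been measured. It differs from compound 2 in one place: a group of 6 heavy atoms (2 carbon, 2 nitrogen, 2 oxygen; one five-membered aromatic ring with 3 hetero atoms) in place of a group of 5 heavy atoms (1 carbon, 4 nitrogen; one five-membered aromatic ring with 4 hetero atoms), on a saturated chain carbon, two bonds along the chain from an aromatic carbon. Going by the values given here, the single measured step concerns a different change, the 2-oxoimidazolidin-1-yl giving way to (1H-tetrazol-5-yl)methyl on the chain carbon bound to the aromatic carbon, so it offers no direct guide to exchanging one five-membered ring for another while the chain itself stays. Among the compounds with values here, with no comparable step available, there is no ground to expect a move beyond the scatter in this assay in either direction. The number for compound 3 is therefore estimated at 130 nM, within 50 nM to 350 nM, which means an expected step of a 1.0-fold lower number from compound 2 to compound 3 (0.01 log units; within the scatter).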

Compound 3, half-maximal inhibitory concentration: 70 nM
Estimate against measurement, compound 3: 1.9-fold (0.27 log units) above; the measured number falls inside the stated range.
By their numbers in this assay, from the lowest: compound 1; then compounds 3 and 2 (each within the scatter of the next).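

Where a five-membered aromatic ring sits on a saturated chain carbon, two bonds along the chain from an aromatic carbon, the exchange of 1H-tetrazol-5-yl for a ring with 3 hetero atoms and a double bond outside the ring gives a 1.9-fold lower number from compound 2 to compound 3 (0.28 log units; within the scatter), so this assay does not tell these two rings apart, and this position accepts more than one ring of this kind. Even so, the 2-oxoimidazolidin-1-yl of compound 1 keeps the lowest number of the set, and the step of a 2.5-fold higher number from compound 1 to compound 3 (0.40 log units; beyond the scatter) shows that the new ring on its chain does not close that gap. No measurement here bears on why these numbers fall as they do.

On these data alone, it remains open how a carboxylic acid would read in place of either ring on the same chain. As far as these compounds go, a longer chain carrying the same ring is equally open.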